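Notes on the step from compound 3 to compound 4

The source may hold more compounds than are shown below. What is called first, only, known or untested is meant among the compounds shown, and "the series" means these compounds.

In an ADME assay on L02 cells (Homo sapiens) for inhibition, read by CCK-8 assay, with a stated time of 48 h (on this read-out lower numbers stand for stronger inhibition of growth and higher numbers for weaker inhibition of growth), compound 1 `CCN1CCN(c2ccc(Nc3ncc(Cl)c(Nc4ccccc4C)n3)nc2)CC1` reads > 100000 nM, which is a limit of the assay and not a number. Two compounds in the series have actual numbers. Compound 2 `CCN1CCN(c2ccc(Nc3ncc(Cl)c(Nc4ccccc4C)n3)cc2)CC1` gives 970 nM and compound 3 `COc1ccc(CNc2nc(Nc3ccc(N4CCN(C)CC4)cn3)ncc2Cl)cc1` gives 12900 nM. Compound 3 therefore holds the higher of the two numbers, standing beyond the scatter from compound 2, which means weaker inhibition of growth.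

Compound 4 `CC(C)c1ccc(Nc2nc(Nc3ccc(N4CCN(C)CC4)cn3)ncc2Cl)cc1` carries 4-isopropylphenyl in place of 4-methoxybenzyl on a nitrogen on an aromatic ring. The same difference, cut one bond further out, reads (4-methoxybenzyl)amino to (4-isopropylphenyl)amino.

Among the measured compounds shown here, no measured pair in this assay shows this kind of change, so the expectation starts from compound 3 at 12900 nM. The expected shift is a 1.2-fold higher number from compound 3 to compound 4 (0.09 log units; within the scatter), a small move toward a higher number that is not expected to lie beyond the scatter. For compound 4 the estimated value is 16000 nM, with an expected range of 3000 nM to 80000 nM.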

Compound 4, concentration for 50% growth inhibition: 13700 nM
The estimate for compound 4 lay 1.2-fold (0.07 log units) above the measured number; low and high end bracket the measured number.
By their numbers in this assay, from the lowest: compound 2; then compounds 3 and 4 (each within the scatter of the next). At a limit, above all of these: compound 1.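

In this assay, the step of 4-isopropylphenyl in place of 4-methoxybenzyl on this nitrogen gives a 1.1-fold higher number from compound 3 to compound 4 (0.03 log units; within the scatter), the only comparison among the compounds shown that differs in one place. At this position, a group of carbon only can therefore replace one carrying an oxygen and a hydrogen-bond acceptor, with the heavy-atom count unchanged and no order between the two compounds on this read-out. Nothing measured here gives a reason for this outcome.

The change alters both the benzyl-to-phenyl attachment and the ring substituent, so the contribution of each cannot be read alone; a methoxyphenyl or isopropylbenzyl group would separate the two. On these data alone, how a ring carrying an amine or a carboxylic acid at this position would read remains open.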